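The source may report more compounds than this note shows. Statements on the series, on what has been measured and on what is new or still open speak of the compounds shown alone.

Compound 1, `O=C(O)/C=C/c1ccc(Cn2cccn2)cc1OCCc1ccc2ccccc2c1`: in an assay on CHO cells for displacement of a labelled ligand from prostaglandin E2 receptor EP1 subtype (Mus musculus), read by scintillation counting (a lower number here means a stronger inhibitor, a higher number a weaker inhibitor), compound 1 gives 2900 nM.
Compound 2, `O=C(O)/C=C/c1ccc(Cn2ccnc2)cc1OCCCOc1ccccc1`: compound 2 reaches only the limit > 10000 nM.
Compound 3, `O=C(O)/C=C/c1ccc(Cn2ccnc2)cc1OCCc1ccc2ccccc2c1`: compound 3 likewise reaches only the limit > 10000 nM.

Among the three measured compounds, compound 3 stands at the limit of this assay, with no number of its own; the limit of > 10000 nM in this assay, at which 2 of the 3 values shown sit, holds for compound 2 as well, so only compound 1 gives a number. Going by the values given here, the one readable step leads into compound 3: an at least 3.4-fold higher number from compound 1 to compound 3 (0.53 log units; beyond the scatter). The other step is a step that the two limits leave unreadable from compound 2 to compound 3, because both of its ends are limits.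

Compound 4, `O=C(O)/C=C/c1ccc(COc2ccccc2)cc1OCCc1ccc2ccccc2c1`, differs from compound 3 in one place: phenoxy in place of 1H-imidazol-1-yl on a saturated chain carbon bound to an aromatic carbon. Among the compounds with values here, no measured step changes this position in the same way, so the measured steps give only indirect guidance. Compound 1 shows that a different small ring at this position gives a number within this assay, while compound 3 shows that the imidazolyl ring does not. The phenoxy group is a new kind of substituent here, and its effect cannot be read from the steps shown. For compound 4, the expected step is an at least 2.0-fold lower number from compound 3 to compound 4 (0.30 log units; that floor lies within the scatter). Compound 4 is therefore estimated at 5000 nM, with a range from 1000 nM to 30000 nM, carrying a sizeable chance of again giving only a limit.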

Compound 4, inhibition constant: > 10000 nM
Compound 4 gave a limit, no number (the forecaster's own chance of this, stated with the estimate: 45%); middle value at least 2.0-fold (0.30 log units) away from the limit.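

In this assay, compound 4 gives only a limit, > 10000 nM, so phenoxy, with its six-membered carbon ring in place of a five-membered aromatic ring with 2 hetero atoms, gives no number at this place on a saturated chain carbon bound to an aromatic carbon. Phenoxy in place of 1H-pyrazol-1-yl gives an at least 3.4-fold higher number from compound 1 to compound 4 (0.53 log units; beyond the scatter), which leaves 1H-pyrazol-1-yl as the only one of the three groups compared on this core to give a number. The step between compound 3 and compound 4 cannot be read, so phenoxy and 1H-imidazol-1-yl cannot be put in order, and most of the set now sits at one limit: the limit of > 10000 nM in this assay, at which 3 of the 4 values shown sit.

The compounds shown leave open whether another ring at this place, such as 1,2,4-triazol-1-yl, or an amine such as morpholine, would give a number, and how far the value of compound 1 could move in either direction. They also leave open whether 1H-pyrazol-1-yl would still give a number with phenoxymethyl in place of naphthalen-2-yl on the chain.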